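The compounds below may be only part of what the source reports. "The series", "measured", "known", "first", "only" and "open" are said of these compounds alone.

Two compounds of this series have numbers in a functional assay on EC9706 cells (Homo sapiens) for cytotoxicity, read by MTT assay, with a stated time of 72 h; on this read-out lower numbers stand for stronger inhibition and higher numbers for weaker inhibition. Compound 1 `CCNC(=O)N1CCN(C(=S)SCc2cn(Cc3ccccc3F)nn2)CC1` gives 23700 nM in this assay, and compound 2 `NC(=O)N1CCN(C(=S)SCc2cn(Cc3ccc(F)cc3)nn2)CC1` gives 62700 nM. Compound 2 therefore stands at the highest of the two numbers; its nearest neighbour is compound 1, whose number is lower by a margin beyond the usual scatter. For the measured compounds named here, no pair of measured compounds differs in one place only, so no single structural step has been resolved so far.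

Compound 3 `CCNC(=O)N1CCN(C(=S)SCc2cn(Cc3ccc(F)cc3)nn2)CC1` has not yet been measured. It differs from compound 2 in one place: ethyl in place of hydrogen on an amide-type nitrogen. Compound 1 carries the same ethylcarbamoyl group but differs from compound 3 elsewhere in the molecule as well, so its number cannot be read as a direct step for this change. On the numbers shown, compound 1 with the ethylcarbamoyl group sits lower than compound 2 with the carbamoyl group. A downward step in this assay is expected, of modest size, a 1.8-fold lower number from compound 2 to compound 3 (0.25 log units; within the scatter), and it may not clear the scatter. Compound 3 is accordingly estimated at 35000 nM, within a range from 14000 nM to 90000 nM.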

Compound 3, half-maximal inhibitory concentration: 27800 nM
For compound 3 the middle estimate is 1.3-fold (0.10 log units) above the measured one, within the range that was stated.
By their numbers in this assay, from the lowest: compounds 1 and 3 (each within the scatter of the next); then compound 2.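

In this assay, ethyl in place of hydrogen on the amide-type nitrogen is now a resolved step (a 2.3-fold lower number from compound 2 to compound 3 (0.35 log units; beyond the scatter)), whereas compound 1 and compound 2 differ in more than one place and could not isolate this change. The second step, 4-fluorophenyl in place of 2-fluorophenyl on the saturated chain carbon bound to an aromatic nitrogen (a 1.2-fold higher number from compound 1 to compound 3 (0.07 log units; within the scatter)), shows that the two fluorophenyl forms cannot be told apart on this read-out while the ethylcarbamoyl group is held constant. No measurement shown here accounts for the step from carbamoyl to ethylcarbamoyl.

The compounds shown leave open how a longer chain such as butyl, or a ring such as cyclohexyl, would read on the amide-type nitrogen, so a single ethyl step gives no trend with chain length. Also open, going by these compounds, is whether the step from carbamoyl to ethylcarbamoyl holds with the 2-fluorophenyl group, and how a 4-chlorophenyl group would read in place of the 4-fluorophenyl group.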